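From hydroxy to methoxy in the ethyl ester series

The source may hold more compounds than are shown below. What is called first, only, known or untested is meant among the compounds shown, and "the series" means these compounds.

Measured so far in a functional assay on the whole organism with Rattus norvegicus as the target; a lower number here means that less compound is needed, a higher number that more compound is needed for the effect:
- Compound 1 `CCOC(=O)C(=O)Nc1nc(-c2ccc(F)cc2)cs1` gives > 10 mg/kg (a limit)
- Compound 2 `CCOC(=O)C(=O)Nc1nc(-c2ccc(O)cc2)cs1` gives about 15 mg/kg (a true number)
- Compound 3 `O=C(O)C(=O)Nc1nc(-c2ccc(O)cc2)cs1` gives > 3 mg/kg (a limit)

Going by the values given here, compound 2 holds the only true number in this small set. The other two results are limits, so compound 2 cannot be ranked against them.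

Compound 4 `CCOC(=O)C(=O)Nc1nc(-c2ccc(OC)cc2)cs1` differs from compound 2 in one place methyl in place of hydrogen on an oxygen on an aromatic ring and the change is methyl in place of hydrogen on an oxygen on an aromatic ring.

Among the compounds with values here, two measured steps bear on this change, though neither has a readable size. The closer one is a step that the limit leaves unreadable from compound 1 to compound 2 and it also alters the group that changes here. The other is a step that the limit leaves unreadable from compound 2 to compound 3 and it concerns the ethyl group instead.

With no measured size to go on, compound 2 at about 15 mg/kg stays the anchor for the expectation. The expected outcome in this assay is no change at the digits printed from compound 2 to compound 4 (within the scatter) with no direction favoured and nothing expected beyond the usual scatter. For compound 4 the estimate is 15 mg/kg with an expected range from 5 mg/kg to 45 mg/kg as a deliberately wide span.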

Compound 4, dose for half-maximal effect: about 10 mg/kg
Compound 4: middle estimate off by 1.5-fold (0.18 log units), on the high side; low and high end bracket the measured number.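

In this assay, methoxy in place of hydroxy gives a 1.5-fold lower number from compound 2 to compound 4 (0.18 log units; within the scatter). Compound 4, like compound 2, gives a true number, so with methyl in place of hydrogen on this oxygen, the effect can still be measured and the dose stays within the usual scatter of compound 2. Methoxy in place of fluoro gives a number no higher from compound 1 to compound 4 (the limit leaves the size open). The size of this step cannot be read, because the result for compound 1 is only a limit: the limit of > 10 mg/kg in this assay, at which 1 of the 4 values shown sits.

From the compounds shown here alone, it remains open how a longer chain on this oxygen, such as propyl, or an amine in place of the hydroxy, would behave in this assay. Also open is whether methoxy would act the same with hydrogen in place of ethyl, as in compound 3, whose result is likewise a limit: the limit of > 3 mg/kg in this assay, at which 1 of the 4 values shown sits.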